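Urea series on the shared core: methoxyphenyl step

The source may hold more compounds than are shown below. What is called first, only, known or untested is meant among the compounds shown, and "the series" means these compounds.

Measured compounds:
compound 1 `O=C(Nc1cccc(Cl)c1)Nc1nnc(Sc2ncnc3scc(-c4ccncc4)c23)s1` — 22900 nM
compound 2 `O=C(Nc1cccc(C(F)(F)F)c1)Nc1nnc(Sc2ncnc3scc(-c4ccncc4)c23)s1` — 15300 nM
compound 3 `Cc1ccc(NC(=O)Nc2nnc(Sc3ncnc4scc(-c5ccncc5)c34)s2)cc1` — 52000 nM

In a functional assay on HepG2 cells (Homo sapiens) for antiproliferative activity, read by MTT assay, with a stated time of 48 h (a higher number here means a weaker inhibitor, a lower number a stronger inhibitor), compound 3 gives the highest number of the three; the step from compound 1 is a 2.3-fold higher number from compound 1 to compound 3 (0.36 log units; beyond the scatter) and the step from compound 2 is a 3.4-fold higher number from compound 2 to compound 3 (0.53 log units; beyond the scatter), both beyond the scatter, so compound 3 is the weakest inhibitor measured. Compound 1 and compound 2 are within the scatter of each other, the step being a 1.5-fold lower number from compound 1 to compound 2 (0.18 log units; within the scatter).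

Compound 4 `COc1cccc(NC(=O)Nc2nnc(Sc3ncnc4scc(-c5ccncc5)c34)s2)c1` is not yet measured. It differs from compound 3 by 3-methoxyphenyl in place of 4-methylphenyl on an amide-type nitrogen. Going by the values given here, the steps that bear on this are those from compound 1 and from compound 2 to compound 3, where the 4-methylphenyl replaced a 3-chlorophenyl or a 3-(trifluoromethyl)phenyl and the number rose modestly each time. Among the compounds with values here, compound 4 returns to a 3-substituted phenyl, now 3-methoxyphenyl, which no measured compound carries. A modest lowering of the number is therefore expected for compound 4, with a 2.1-fold lower number from compound 3 to compound 4 (0.32 log units; beyond the scatter), the direction resting on a 2.3-fold higher number from compound 1 to compound 3 (0.36 log units; beyond the scatter) and a 3.4-fold higher number from compound 2 to compound 3 (0.53 log units; beyond the scatter). The estimate for compound 4 in this assay is 25000 nM, with a range from 10000 nM to 60000 nM.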

Compound 4, half-maximal inhibitory concentration: 28400 nM
Compound 4: middle estimate off by 1.1-fold (0.06 log units), on the low side; the measured number falls inside the stated range.
By their numbers in this assay, from the lowest: compounds 2, 1, 4 and 3 (each within the scatter of the next, the first and the last beyond it).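

In this assay, methoxy does not separate from the other two groups on the 3-substituted phenyl (a 1.2-fold higher number from compound 1 to compound 4 (0.09 log units; within the scatter); a 1.9-fold higher number from compound 2 to compound 4 (0.27 log units; within the scatter)), so chloro, trifluoromethyl and methoxy read alike in these compounds. The step from the 4-methylphenyl compound also lies within the scatter (a 1.8-fold lower number from compound 3 to compound 4 (0.26 log units; within the scatter)), so carrying a 3-substituted phenyl does not by itself set compound 4 apart from compound 3, although compound 1 and compound 2 are both set apart from it. Nothing on hand explains any of these steps.

This step changes both the group and its place on the phenyl at once, and a 3-methylphenyl or a 4-methoxyphenyl on the same nitrogen would pull those two apart. On these data alone, how a 3-aminophenyl or a 3-carboxyphenyl would read remains open.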